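Working Notes: Hydroxy in Place of Hydrogen, Compound 4

A few compounds are considered here, and "the series" means these few. Any claim that something is new, unique, unknown or untested is made for them only; others in the source may bear on it.

In a functional assay on K562 cells (Homo sapiens) for antiproliferative activity, read by MTT assay, with a stated time of 48 h (a lower number here means a stronger inhibitor, a higher number a weaker inhibitor), compound 1 `CN(C)C(=O)N(Cc1cccc([N+](=O)[O-])c1)Cc1ccco1` gives 35400 nM. Compound 3 `CN(C)C(=O)N(Cc1ccc([N+](=O)[O-])cc1)Cc1ccco1` gives 35400 nM in this assay, level with compound 1 at the digits shown, and compound 2 `CCOC(=O)N1CCC(N(Cc2ccc(O)cc2)C(=O)N(C)C)CC1` gives 41800 nM, a number within the scatter of the other two. The three numbers show no ordering that can be trusted, and all sit at the weak end of what this read-out resolves. Compound 4 `CN(C)C(=O)N(Cc1ccco1)Cc1cc([N+](=O)[O-])ccc1O` differs from compound 1 by hydroxy in place of hydrogen on an aromatic carbon. Among the compounds with values here, no measured pair in the set carries this change, so there is nothing to anchor the size of the step; no step beyond the scatter is expected in this assay, in either direction. Compound 4 is estimated at 35000 nM, range 12000 nM to 100000 nM. The step of a 1.0-fold lower number from compound 1 to compound 4 (0.00 log units; within the scatter) is expected to stay within the scatter.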

Compound 4, half-maximal inhibitory concentration: 28600 nM
Estimate against measurement, compound 4: 1.2-fold (0.09 log units) above, within the range that was stated.
By their numbers in this assay, from the lowest: compounds 4, 1, 3 and 2 (each within the scatter of the next).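

In this assay, within the data shown here, hydroxy in place of hydrogen on an aromatic carbon, ortho to a large group and para to a nitro group, gives a 1.2-fold lower number from compound 1 to compound 4 (0.09 log units; within the scatter) and is the only measured change at this position. A hydroxy is thus accommodated on this carbon with no step beyond the scatter. Nothing available explains this result.

From the compounds shown here alone, whether a methoxy or an amine on the same carbon would give a step beyond the scatter remains open. So does the effect of a carboxylic acid there.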